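Methyl added to the aryl sulfonamide series

This account rests on a few compounds, and the source may have more. Where it says the series, first, only, none or still open, it means among the compounds named here.

Measured so far:
compound 1 `Cc1cccc(NS(=O)(=O)c2ccc(N3CCNC3=O)cc2)c1` — 190 nM
compound 2 `COc1ccc(NS(=O)(=O)c2ccc(N3CCNC3=O)cc2)cc1OC` — 610 nM
compound 3 `O=C1NCCN1c1ccc(S(=O)(=O)Nc2ccc3c(c2)CCC3)cc1` — 240 nM

All three carry the same core and differ only in the aryl group on the sulfonamide nitrogen. In a functional assay on MCF7 cells (Homo sapiens) for antiproliferative activity, read by sulforhodamine B assay, with a stated time of 48 h (a lower number here means a stronger inhibitor, a higher number a weaker inhibitor), compound 1 gives 190 nM, the lowest of the three numbers. Compound 3 gives 240 nM, which lies within the scatter of compound 1. Compound 2 gives 610 nM, a gap beyond the scatter from compound 1.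

Compound 4 `Cc1ccc(C)c(NS(=O)(=O)c2ccc(N3CCNC3=O)cc2)c1` has not yet been measured in this assay. Against compound 1 the difference is methyl in place of hydrogen on an aromatic carbon. Within the data shown here, no pair of measured compounds shows this change, so its size cannot be read from the data. The expectation is a step of a 1.1-fold higher number from compound 1 to compound 4 (0.02 log units; within the scatter), not beyond the scatter. Compound 4 is therefore estimated at 200 nM, with a range from 80 nM to 500 nM.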

Compound 4, half-maximal inhibitory concentration: 48 nM
Compound 4: middle estimate off by 4.2-fold (0.62 log units), on the high side; the measured number lies below the stated range.
By their numbers in this assay, from the lowest: compound 4; then compounds 1 and 3 (each within the scatter of the next); then compound 2.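

Methyl in place of hydrogen on this aromatic carbon, ortho to a large group and para to a methyl group, gives a 4.0-fold lower number from compound 1 to compound 4 (0.60 log units; beyond the scatter). Among these compounds, this is the first single-change step, and it shows that the 3-methylphenyl to 2,5-dimethylphenyl change can move the number beyond the scatter. Nothing available explains the step.

Still open, as far as these compounds go, is whether this methyl gives the same step without the methyl group para to it. Also open, from the compounds shown here alone, is how an ethyl group, a chlorine atom or an amine would read on the same carbon.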